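Urea terminus trimmed: from cyclopropyl to ethyl

The source may hold more compounds than are shown below. What is called first, only, known or untested is meant among the compounds shown, and "the series" means these compounds.

This account concerns a series sharing one core, in which three compounds have been measured in a functional assay on HUVEC cells (Homo sapiens) for antiproliferative activity, read by sulforhodamine B assay, with a stated time of 48 h; on this read-out lower numbers stand for stronger inhibition and higher numbers for weaker inhibition. Compound 1 `CN1CCC(COc2ccc3c(Nc4ccc(NC(=O)Nc5ccc(Cl)c(C(F)(F)F)c5)cc4)ncnc3c2)CC1` gives 92 nM in this assay. Compound 3 `CN1CCC(COc2ccc3c(Nc4ccc(NC(=O)Nc5cccc(F)c5)c(F)c4)ncnc3c2)CC1` gives 67 nM in this assay. Compound 2 `CN1CCC(COc2ccc3c(Nc4ccc(NC(=O)NC5CC5)cc4)ncnc3c2)CC1` gives 324 nM in this assay, and it stands highest of the three numbers, with compound 1 nearest and compound 3 furthest. Among the compounds with values here, the only single-site step measured so far, a 3.5-fold higher number from compound 1 to compound 2 (0.55 log units; beyond the scatter), trades an aromatic group on the urea for a small carbocycle.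

Compound 4 `CCNC(=O)Nc1ccc(Nc2ncnc3cc(OCC4CCN(C)CC4)ccc23)cc1` is not yet measured. It differs from compound 2 by ethyl in place of cyclopropyl on an amide-type nitrogen. Within the data shown here, no measured step bears on this change directly: the only step, a 3.5-fold higher number from compound 1 to compound 2 (0.55 log units; beyond the scatter), concerns a different kind of exchange, so it tells little about cyclopropyl against ethyl at the same place. Both groups are small, and the remainder of the molecule is unchanged, so the expected step from compound 2 to compound 4, a 1.2-fold higher number from compound 2 to compound 4 (0.09 log units; within the scatter), is estimated to lie within the scatter, with no confident direction. Compound 4 is therefore expected to give about 400 nM in this assay, within a range from 180 nM to 900 nM.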

Compound 4, half-maximal inhibitory concentration: 587 nM
The estimate for compound 4 lay 1.5-fold (0.17 log units) below the measured number; the measured number falls inside the stated range.
By their numbers in this assay, from the lowest: compounds 3 and 1 (each within the scatter of the next); then compounds 2 and 4 (each within the scatter of the next).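

In this assay, ethyl in place of cyclopropyl on the amide-type nitrogen gives a 1.8-fold higher number from compound 2 to compound 4 (0.26 log units; within the scatter) and so leaves the two compounds within the scatter of each other; the three-membered ring and the extra carbon of cyclopropyl therefore show no measurable effect at this place. The exchange of 4-chloro-3-(trifluoromethyl)phenyl for ethyl gives a 6.4-fold higher number from compound 1 to compound 4 (0.80 log units; beyond the scatter) and, read with a 3.5-fold higher number from compound 1 to compound 2 (0.55 log units; beyond the scatter) for cyclopropyl at the same nitrogen, shows that the higher number is not particular to cyclopropyl but holds for both of the small groups shown, each of them beyond the scatter of the aryl compound. The data shown offer no independent measurement that would account for this difference between the aromatic group and the two small groups.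

As far as these compounds go, whether a longer chain such as butyl, or an ethyl carrying an amine or a hydroxyl group, would stay with compound 2 and compound 4 or move towards compound 1 remains open. So does the question of whether an unsubstituted phenyl on this nitrogen, without the chlorine and the trifluoromethyl, would match compound 1 or fall with the small groups.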